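Removing a pyrazole methyl where binding is already undetectable

The compounds below may be only part of what the source reports. "The series", "measured", "known", "first", "only" and "open" are said of these compounds alone.

Of the compounds shown here, three have been measured in an assay on membranes from brain for binding affinity to neutral cholesterol ester hydrolase 1 (Mus musculus), read by fluorescence, with stated times of 1 h and 30 min; a lower number here means a stronger inhibitor, a higher number a weaker inhibitor. Compound 1 `Cc1cnn(C(=O)NCc2ccc(OCc3ccccc3)cc2)c1` carries a 4-methyl-1H-pyrazol-1-yl group on an amide. Compound 2 `O=C(NCc1ccc(OCc2ccccc2)cc1)n1cccn1` differs by hydrogen in place of methyl on an aromatic carbon. In this assay compound 1 gives > 100000 nM, which is a limit of the assay rather than a number. Likewise compound 2 gives > 100000 nM, again a limit. The step that the two limits leave unreadable from compound 1 to compound 2 therefore cannot be sized. Compound 3 `Cc1cnn(C(=O)N2CCN(C(c3ccc4ccccc4c3)c3ccc4ccccc4c3)CC2)c1` joins the same methylated pyrazole to a different core; the difference between the two cores is not broken down here. Compound 3 gives > 100000 nM, also a limit. Compound 4 `O=C(N1CCN(C(c2ccc3ccccc3c2)c2ccc3ccccc3c2)CC1)n1cccn1` has not yet been measured; it differs from compound 3 by hydrogen in place of methyl on an aromatic carbon, the same change as between compound 1 and compound 2. Compound 4 is expected to give 200000 nM. The step that the limit leaves unreadable from compound 3 to compound 4 is expected to be no real movement, because every measured value rests at the limit of > 100000 nM in this assay, at which 3 of the 3 values shown sit. Compound 4 is thus estimated to remain beyond measurable binding.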

Compound 4, half-maximal inhibitory concentration: > 100000 nM
Compound 4: no number, only a limit; the forecaster's own chance of this, stated with the estimate: 90%; the middle value lies beyond the limit too.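

Compound 3 and compound 4 both sit at a limit of the assay rather than at a number, so the change from 4-methyl-1H-pyrazol-1-yl to 1H-pyrazol-1-yl yields no readable step between them: the limit of > 100000 nM in this assay, at which 4 of the 4 values shown sit. The compounds shown leave open whether this change would shift binding in this assay for a compound with a measurable value.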